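Two Chlorines on a Triazole Series and Cytotoxicity

The source may report more compounds than this note shows. Statements on the series, on what has been measured and on what is new or still open speak of the compounds shown alone.

The study began with compound 1 `CC[C@H](CCn1cncn1)c1ccccc1`, which in an ADME assay on RD cells (Homo sapiens) for cytotoxicity, read by MTT assay, with a stated time of 3 days (on this read-out higher numbers stand for lower toxicity in this test and lower numbers for higher toxicity in this test), gives 99.8 ug/mL. Compound 2 `CC[C@H](CCn1cncn1)c1ccc(Cl)cc1` carries chloro in place of hydrogen on an aromatic carbon, placed para to a large group, and in this assay compound 2 gives 57 ug/mL; the step is a 1.8-fold lower number from compound 1 to compound 2 (0.24 log units; within the scatter). Compound 3 `Clc1ccc([C@@H](CCn2cncn2)Cc2ccccc2)cc1` extends the chain, and in this assay compound 3 gives 24.4 ug/mL, the step from compound 2 being a 2.3-fold lower number from compound 2 to compound 3 (0.37 log units; beyond the scatter). Compound 3 thus has the lowest number of the three measured compounds, with compound 2 nearest and compound 1 furthest.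

Compound 4 `Clc1ccc([C@@H](CCn2cncn2)Cc2ccccc2)c(Cl)c1` is the unmeasured member. Relative to compound 3 it carries chloro in place of hydrogen on an aromatic carbon, sitting ortho to a large group and meta to a chloro group, whereas in the change from compound 1 to compound 2 the chloro enters para to a large group. The two changes are therefore the same kind of change rather than the same change, and the difference between the core of compound 1 and the core of compound 3 is not broken down here.

Given that the earlier chloro addition gave a 1.8-fold lower number from compound 1 to compound 2 (0.24 log units; within the scatter), a step of similar size and direction is expected for compound 4, namely a 1.6-fold lower number from compound 3 to compound 4 (0.21 log units; within the scatter). On that basis compound 4 is estimated to give about 15 ug/mL in this assay, likely falling between 7 ug/mL and 35 ug/mL.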

Compound 4, half-maximal cytotoxic concentration: 6.5 ug/mL
Beside the measured number, compound 4's estimate is 2.3-fold (0.36 log units) above it; measured number outside the range, below it.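

In this assay, chloro in place of hydrogen on an aromatic carbon, ortho to a large group and meta to a chloro group, gives a 3.8-fold lower number from compound 3 to compound 4 (0.57 log units; beyond the scatter). Set beside the earlier chloro addition, this step is the larger on paper, but the gap between the two does not exceed what repeated measurement allows: the same change on two cores in this assay, a 1.8-fold lower number (0.24 log units; within the scatter) from compound 1 to compound 2 and a 3.8-fold lower number (0.57 log units; beyond the scatter) from compound 3 to compound 4, 2.1-fold (0.33 log units) apart, within the scatter of two such steps. Within the data shown here, the change therefore carries from one core to the other with no size difference that can be told apart, although only the step to compound 4 lies beyond the scatter by itself, and with one pair per core and the chloro entering at a different place on the ring in each pair, the data cannot separate an effect of the core from an effect of the position.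

The compounds shown leave open what the same core gives with a chloro only at the new place, without the other chloro on the ring. They also leave open whether a fluoro or methoxy group at that place, or a longer chain in place of the phenyl on the saturated chain, would move the number in the same direction.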